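Thiophen-3-yl for Phenyl on Two Related Nucleoside Cores

The source may hold more compounds than are shown below. What is called first, only, known or untested is meant among the compounds shown, and "the series" means these compounds.

compound 1, `COc1nc(N)nc2c1c(-c1ccccc1)cn2[C@@H]1O[C@H](CO)[C@@H](O)[C@H]1O`: > 20000 nM
compound 2, `COc1nc(N)nc2c1c(-c1ccsc1)cn2[C@@H]1O[C@H](CO)[C@@H](O)[C@H]1O`: > 20000 nM
compound 3, `Nc1nc2c(c(-c3ccccc3)cn2[C@@H]2O[C@H](CO)[C@@H](O)[C@H]2O)c(=O)[nH]1`: > 100000 nM

All three were tested in a functional assay on CCRF-CEM cells (Homo sapiens), read by MTT assay, with a stated time of 72 h; a higher number here means a weaker inhibitor, a lower number a stronger inhibitor. For compound 1 the value is a limit of the assay, not a number. For compound 2 the value is likewise a limit, and both of these sit at the limit of > 20000 nM in this assay, at which 2 of the 3 values shown sit. The change between them is thiophen-3-yl in place of phenyl on an aromatic carbon, and it gives a step that the two limits leave unreadable from compound 1 to compound 2. For compound 3 the value is a limit too, at the limit of > 100000 nM in this assay, at which 1 of the 3 values shown sits. How the core of compound 3 differs from the core of compound 1 is not broken down here.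

Compound 4, `Nc1nc2c(c(-c3ccsc3)cn2[C@@H]2O[C@H](CO)[C@@H](O)[C@H]2O)c(=O)[nH]1`, has not been measured. It differs from compound 3 by thiophen-3-yl in place of phenyl on an aromatic carbon, the same kind of change as that from compound 1 to compound 2; around the place, the bearing ring atom carries a group of 9 heavy atoms in one case and the 3,4-dihydroxy-5-(hydroxymethyl)oxolan-2-yl group in the other. Because compound 3 sits at the limit of > 100000 nM in this assay, at which 1 of the 3 values shown sits, and because the earlier step is a step that the two limits leave unreadable from compound 1 to compound 2, compound 4 is expected to show a step that the limit leaves unreadable from compound 3 to compound 4. Compound 4 is therefore estimated at 150000 nM, between 50000 nM and 500000 nM, most probably again reported only as a limit.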

Compound 4, half-maximal inhibitory concentration: > 20000 nM
Compound 4 ended at the assay's limit; the forecaster's own chance of this, stated with the estimate: 85%; the middle value does not contradict the limit.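

In this assay compound 3 gives > 100000 nM, which is a limit and not a number. Compound 4 gives > 20000 nM, also a limit, so no step can be read between compound 3 and compound 4. The compounds shown leave open how strongly any of them inhibits, and whether thiophen-3-yl in place of phenyl changes that on either core.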